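Extending the ether branch from isobutoxy to neopentyloxy

This account rests on a few compounds, and the source may have more. Where it says the series, first, only, none or still open, it means among the compounds named here.

Compound 1 `CCCOc1cc(C(C)(C)C)ccc1CNC(=O)C(C)c1ccc(NS(C)(=O)=O)c(F)c1` and compound 2 `CC(C)COc1cc(C(C)(C)C)ccc1CNC(=O)C(C)c1ccc(NS(C)(=O)=O)c(F)c1` share one core and differ only in the ether chain. In an assay on cells for antagonist activity at transient receptor potential cation channel subfamily V member 1 (Homo sapiens), read by FLIPR and calcium flux, with a stated time of 6 min (on this read-out higher numbers stand for weaker inhibition and lower numbers for stronger inhibition), compound 1 gives 4.4 nM, and compound 2 gives 2.1 nM. Compound 2 thus holds the lower of the two numbers, and the step of a 2.1-fold lower number from compound 1 to compound 2 (0.32 log units; beyond the scatter) is modest but beyond the scatter. Compound 3 `CC(C(=O)NCc1ccc(C(C)(C)C)cc1OCC(C)(C)C)c1ccc(NS(C)(=O)=O)c(F)c1` carries the change (methyl in place of hydrogen on a saturated chain carbon bound to three saturated chain carbons); one bond further out this reads isobutoxy to neopentyloxy. Within the data shown here, the only measured step that bears on it is a 2.1-fold lower number from compound 1 to compound 2 (0.32 log units; beyond the scatter), where a methyl added on a saturated chain carbon bound to two saturated chain carbons lowered the number a little. A further methyl on the same carbon is expected to give a small step in this assay, possibly none beyond the scatter. Compound 3 is therefore estimated at 1.6 nM, within 0.5 nM to 5 nM, meaning an expected step of a 1.3-fold lower number from compound 2 to compound 3 (0.12 log units; within the scatter).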

Compound 3, inhibition constant: 3.8 nM
Compound 3: the middle estimate sits 2.4-fold (0.38 log units) below what was measured; measured number inside the range.
By their numbers in this assay, from the lowest: compounds 2, 3 and 1 (each within the scatter of the next, the first and the last beyond it).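

The second methyl on this ether branch gives a 1.8-fold higher number from compound 2 to compound 3 (0.26 log units; within the scatter) in this assay and so does not repeat the lowering seen with the first methyl, which stood beyond the scatter. Read across both added methyls, tert-butyl in place of ethyl on a saturated chain carbon bound to an oxygen on an aromatic ring gives a 1.2-fold lower number from compound 1 to compound 3 (0.06 log units; within the scatter), so the fully branched chain end is accepted here but brings no measurable gain over the unbranched ether chain of compound 1. Nothing given here accounts for these numbers.

As far as these compounds go, whether a longer chain, or a cyclopropyl ring or an amine at the end of the ether chain, would hold or shift the number stays open. So does whether compound 2 and compound 3 would separate on any other read-out.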